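Vero cell tolerance: bromo to trifluoromethyl

This account rests on a few compounds, and the source may have more. Where it says the series, first, only, none or still open, it means among the compounds named here.

Compound 1 `COc1nc(-c2ccc(Br)cc2)ccc1[C@@H](c1ccccc1)[C@@](O)(CCN(C)C)c1cccc2ccccc12` is the reference point of the series. In a toxicity assay on Vero cells (Chlorocebus sabaeus) for cytotoxicity (a higher number here means that more compound is tolerated, a lower number that less compound is tolerated), compound 1 gives > 50 ug/mL, which is a limit of the assay and not a number. Compound 2 `COc1ncc(-c2ccccc2)cc1[C@@H](c1ccccc1)[C@@](O)(CCN(C)C)c1cc(F)ccc1F` gives > 50 ug/mL in this assay, also a limit. Compound 3 `COc1ncc(-c2ccccc2)cc1[C@@H](c1ccccc1)[C@@](O)(CCN(C)C)c1ccccc1` gives > 50 ug/mL in this assay, again a limit. Among the compounds with values here, the only single-change step among the measured compounds, a step that the two limits leave unreadable from compound 2 to compound 3, is therefore unreadable. Compound 4 `COc1nc(-c2ccc(C(F)(F)F)cc2)ccc1[C@@H](c1ccccc1)[C@@](O)(CCN(C)C)c1cccc2ccccc12` differs from compound 1 by trifluoromethyl in place of bromo on an aromatic carbon. Within the data shown here, no measured step bears directly on this exchange; what the numbers show is the limit of > 50 ug/mL in this assay, at which 3 of the 3 values shown sit. Compound 4 is therefore expected to remain at that limit, with an expected step that the limit leaves unreadable from compound 1 to compound 4 of no readable size. The estimate for compound 4 in this assay is 60 ug/mL, within 35 ug/mL to 120 ug/mL.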

Compound 4, half-maximal cytotoxic concentration: > 50 ug/mL
Compound 4: no number, only a limit; the forecaster's own chance of this, stated with the estimate: 85%; the middle value is on the limit's open side.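

No size can be read for the exchange of bromo for trifluoromethyl from compound 1 to compound 4: in this assay both give only limits, not numbers. The compounds shown leave open at what concentration any of them stops being tolerated in this assay.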